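Fluoro to Bromo: Expecting Little Change in Cytotoxicity

This account rests on a few compounds, and the source may have more. Where it says the series, first, only, none or still open, it means among the compounds named here.

Of the compounds shown here, three of one series have been measured in an ADME assay on CCRF-CEM cells (Homo sapiens) for cytotoxicity, with a stated time of 72 h; on this read-out higher numbers stand for weaker inhibition and lower numbers for stronger inhibition. Compound 1 `Clc1ccc(Cc2nn3cc(-c4ccc(Br)cc4)nc3s2)cc1` reached (the limit of > 250000 nM in this assay, at which 1 of the 3 values shown sits), so for compound 1 only the limit > 250000 nM is known rather than a number. Compound 2 `Clc1ccc(Cc2nn3c(Br)c(-c4ccc(Br)cc4)nc3s2)cc1` carries bromo in place of hydrogen on the shared core, and in this assay compound 2 gives 238000 nM; the step of an at least 1.0-fold lower number from compound 1 to compound 2 (0.02 log units; that floor lies within the scatter) lies within the usual scatter. Compound 3 `N#CSc1c(-c2ccc(F)cc2)nc2sc(Cc3ccc(Cl)cc3)nn12` gives 24000 nM in this assay, the lowest of the two numbers available, and its gap to compound 2 lies beyond the scatter.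

Compound 4 `N#CSc1c(-c2ccc(Br)cc2)nc2sc(Cc3ccc(Cl)cc3)nn12` has not yet been measured. Compared with compound 3, it shows (bromo in place of fluoro on an aromatic carbon). Going by the values given here, the only measured step, from compound 1 to compound 2, concerns a different exchange at a different place and was within the scatter, so no measured step bears directly on this halogen swap. With nothing pointing to a shift in either direction, the expectation for the step of no change at the digits printed from compound 3 to compound 4 (within the scatter) is one that stays within the scatter. Compound 4 is therefore estimated to give 24000 nM in this assay, with a range from 8000 nM to 72000 nM.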

Compound 4, half-maximal inhibitory concentration: 61000 nM
Compound 4: the middle estimate sits 2.5-fold (0.41 log units) below what was measured; the range from low to high includes it.
By their numbers in this assay, from the lowest: compound 3; then compound 4; then compound 2. At a limit, above all of these: compound 1.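

The result shows that the halogen on this phenyl ring matters in this assay: a 2.5-fold higher number from compound 3 to compound 4 (0.41 log units; beyond the scatter). Going by these compounds alone, exchanging 4-fluorophenyl for 4-bromophenyl replaces one heavy atom with one heavy atom, yet this step lies beyond the usual scatter, whereas the only earlier step between measured compounds lay within it. The new compound also gives the first clean view of the cyanosulfanyl group with 4-bromophenyl held fixed, since cyanosulfanyl in place of bromo gives a 3.9-fold lower number from compound 2 to compound 4 (0.59 log units; beyond the scatter) and cyanosulfanyl in place of hydrogen gives an at least 4.0-fold lower number from compound 1 to compound 4 (0.61 log units; beyond the scatter). Compound 1 is known only as a limit, so that last step is a floor rather than an exact size: the limit of > 250000 nM in this assay, at which 1 of the 4 values shown sits.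

As far as these compounds go, how chloro, a methoxy group or an amine on the same phenyl ring would compare with fluoro and bromo remains open. Also open, from the compounds shown here alone, is whether the lower numbers depend on cyanosulfanyl itself, or whether a carboxylic acid or a longer alkyl chain at that place on the shared core would give similar values.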